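This account rests on a few compounds, and the source may have more. Where it says the series, first, only, none or still open, it means among the compounds named here.

Compound 3 `COc1ccccc1Nc1ncnc2cc(OC)c(OCCCCC(=O)Nc3ccc(S(N)(=O)=O)cc3)cc12` holds the lowest of the numbers reported for this series: in a functional assay on NCI-H1975 cells (Homo sapiens) for antiproliferative activity, read by MTT assay, with a stated time of 72 h (a higher number here means a weaker inhibitor, a lower number a stronger inhibitor), compound 3 gives 8030 nM. Compound 1 `C#Cc1cccc(Nc2ncnc3cc(OC)c(OCCCCC(=O)Nc4ccc(S(N)(=O)=O)cc4)cc23)c1` gives 18800 nM in this assay, so the step of a 2.3-fold lower number from compound 1 to compound 3 (0.37 log units; beyond the scatter) is modest yet beyond the scatter. Compound 2 `COc1cc2ncnc(Nc3cccc(F)c3)c2cc1OCCCCC(=O)Nc1ccc(S(N)(=O)=O)cc1` gives > 40000 nM in this assay, which is a limit of the assay and not a number. the limit of > 40000 nM in this assay, at which 1 of the 3 values shown sits, records that one of the three values sits at this limit. The step of an at least 4.9-fold lower number from compound 2 to compound 3 (0.69 log units; beyond the scatter) is therefore known only as a bound, and so is an at least 2.1-fold higher number from compound 1 to compound 2 (0.32 log units; beyond the scatter).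

Compound 4 `COc1cc2ncnc(Nc3ccc(C(F)(F)F)cc3)c2cc1OCCCCC(=O)Nc1ccc(S(N)(=O)=O)cc1` has not yet been measured. Relative to compound 3 it carries 4-(trifluoromethyl)phenyl in place of 2-methoxyphenyl on a nitrogen on an aromatic ring. The two measured steps that alter the same aryl group, a 2.3-fold lower number from compound 1 to compound 3 (0.37 log units; beyond the scatter) and an at least 4.9-fold lower number from compound 2 to compound 3 (0.69 log units; beyond the scatter), were both modest in size, and each ended at the 2-methoxyphenyl compound with the lowest number. The change to compound 4 leaves that group again, so a modest rise in number in this assay is expected, near what the other two aryl groups gave. Compound 4 is expected to give about 20000 nM in this assay, within a range of 8000 nM to 50000 nM. The step this estimate implies is a 2.5-fold higher number from compound 3 to compound 4 (0.40 log units; beyond the scatter).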

Compound 4, half-maximal inhibitory concentration: 12000 nM
For compound 4 the middle estimate is 1.7-fold (0.22 log units) above the measured one, within the range that was stated.
By their numbers in this assay, from the lowest: compounds 3, 4 and 1 (each within the scatter of the next, the first and the last beyond it). At a limit, above all of these: compound 2.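

At this position, on a nitrogen on an aromatic ring, 4-(trifluoromethyl)phenyl replaces 2-methoxyphenyl with a 1.5-fold higher number from compound 3 to compound 4 (0.17 log units; within the scatter) in this assay, so the separation that 2-methoxyphenyl showed from the two earlier aryl groups does not extend to this one. Against 3-ethynylphenyl, the same change gives a 1.6-fold lower number from compound 1 to compound 4 (0.19 log units; within the scatter), so 4-(trifluoromethyl)phenyl cannot be told apart from either of these two groups, even though those two lie beyond the scatter of each other. Only 3-fluorophenyl stays apart, with an at least 3.3-fold lower number from compound 2 to compound 4 (0.52 log units; beyond the scatter), a step known only as a bound since it rests on a limit of the assay and not a number: the limit of > 40000 nM in this assay, at which 1 of the 4 values shown sits.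

These four compounds differ only in the aryl group on that nitrogen, and their values do not tell which feature of that group sets the number. Also open, going by these compounds, is whether an aryl group carrying an amine changes the number here, and whether a longer chain or a carboxylic acid in place of the sulfonamide moves it further than any aryl change has so far.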